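The source may report more compounds than this note shows. Statements on the series, on what has been measured and on what is new or still open speak of the compounds shown alone.

Of the compounds shown here, three sharing one core have been tested in a functional assay on MDA-MB-231 cells (Homo sapiens) for antiproliferative activity, read by MTT assay, with a stated time of 72 h; on this read-out higher numbers stand for weaker inhibition and lower numbers for stronger inhibition. Compound 1 `CCCn1ccnc1-c1cc(OC)c(OC)c(OC)c1` reads > 100000 nM, which is a limit of the assay and not a number. Compound 2 `COc1cc(-c2nccn2CC(C)C)cc(OC)c1OC`, with isobutyl on an aromatic nitrogen, reads > 100000 nM, again only a limit. Compound 3 `COc1cc(-c2nccn2-c2cccc([N+](=O)[O-])c2)cc(OC)c1OC`, with an aromatic ring on that nitrogen, reads > 100000 nM, also a limit. Compound 2 therefore has no number of its own, and the whole picture so far is the limit of > 100000 nM in this assay, at which 3 of the 3 values shown sit.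

The next compound is compound 4 `COc1cc(-c2nccn2-c2ccc(Br)cc2)cc(OC)c1OC`, where the change is 4-bromophenyl in place of isobutyl on an aromatic nitrogen. Among the compounds with values here, the one measured step is a step that the two limits leave unreadable from compound 1 to compound 2, so it offers no size to carry over. Compound 3 is the closest guide, since it also has an aromatic ring at this place, yet it gives no number in this assay. A large gain is therefore not expected. Only movement towards stronger inhibition could show up as a number, so any readable change should lie in that direction. The expected size is an at least 1.6-fold lower number from compound 2 to compound 4 (0.22 log units; that floor lies within the scatter), and this remains a cautious estimate. For compound 4 the estimated value is 60000 nM, with an expected range from 12000 nM to 100000 nM.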

Compound 4, half-maximal inhibitory concentration: 8400 nM
Compound 4: the middle estimate sits 7.1-fold (0.85 log units) above what was measured; the measured number lies below the stated range.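

In this assay, the group on this aromatic nitrogen can now be seen to matter, since replacing isobutyl with 4-bromophenyl gives an at least 11-fold lower number from compound 2 to compound 4 (1.07 log units; beyond the scatter), and replacing propyl with the same group gives an at least 11-fold lower number from compound 1 to compound 4 (1.07 log units; beyond the scatter). Compound 3 gives > 100000 nM, which is a limit of the assay and not a number, so an aromatic ring at this place does not bring a readable value on its own, and the nitro-bearing ring of compound 3 and the 4-bromophenyl ring of compound 4 cannot be ranked by size of effect. Compound 4 is the first to give a number of its own, so it is a single reading point rather than a trend: the limit of > 100000 nM in this assay, at which 3 of the 4 values shown sit.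

The compounds shown leave open whether the gain depends on the bromine itself, which a plain phenyl ring or a 4-chlorophenyl ring at this nitrogen would help to test. They also leave open how far a readable value can go with other groups on that ring, such as methoxy or an amine, and why 4-bromophenyl behaves as it does.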